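Trading an aromatic ring for a saturated one

This account rests on a few compounds, and the source may have more. Where it says the series, first, only, none or still open, it means among the compounds named here.

Measured so far:
- Compound 1, `Cc1cc(C)c(CN2CCc3c(Cl)cc([C@@H](CO)[C@@H]4CCOC4)c(Cl)c3C2=O)c(=O)[nH]1`: in an ADME assay on microsomes from liver (Homo sapiens) for metabolic stability, read by LC-MS, using NADPH, with stated times of 10 min and 45 min, tested at 1 uM (on this read-out higher numbers stand for fast clearance and lower numbers for slow clearance), compound 1 gives 25.3 uL/min
- Compound 2, `Cc1cc(C)c(CN2CCc3c(Cl)cc(-c4c(C)noc4C)c(Cl)c3C2=O)c(=O)[nH]1`: in this assay compound 2 gives 107 uL/min

Among these two numbers compound 2 stands highest, with compound 1 as its only neighbour, and the step between them, a 4.2-fold higher number from compound 1 to compound 2 (0.63 log units; beyond the scatter), lies beyond the scatter. Compound 3, `Cc1cc(C)c(CN2CCc3c(Cl)cc([C@@H](CO)[C@H]4CCCO4)c(Cl)c3C2=O)c(=O)[nH]1`, has not yet been measured. It departs from compound 2 at one point: a group of 8 heavy atoms (6 carbon, 2 oxygen; one five-membered non-aromatic ring with 1 hetero atom) in place of a group of 7 heavy atoms (5 carbon, 1 nitrogen, 1 oxygen; one five-membered aromatic ring with 2 hetero atoms), on an aromatic carbon. The group that enters is a close relative of the group that sits at the same place in compound 1; the two differ only in where the oxygen sits within the five-membered non-aromatic ring, and both carry a hydroxyl-bearing chain with defined stereocentres. Going by the values given here, the one step that bears on this change is therefore the move from compound 1 to compound 2, read backwards. Because a 4.2-fold higher number from compound 1 to compound 2 (0.63 log units; beyond the scatter) was a modest rise when the aromatic ring replaced the saturated one, putting a saturated ring back is expected to bring a fall of similar size, a 3.8-fold lower number from compound 2 to compound 3 (0.58 log units; beyond the scatter). On that basis compound 3 is estimated at 28 uL/min, with a likely range from 12 uL/min to 65 uL/min.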

Compound 3, intrinsic clearance in a liver preparation (reported as CLH), per the amount of preparation that the assay uses: 43 uL/min
The estimate for compound 3 lay 1.5-fold (0.19 log units) below the measured number, within the range that was stated.
By their numbers in this assay, from the lowest: compounds 1 and 3 (each within the scatter of the next); then compound 2.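

In this assay the 3,5-dimethyl-1,2-oxazol-4-yl group gives way to a second saturated group on the same aromatic carbon, and the number falls again (a 2.5-fold lower number from compound 2 to compound 3 (0.40 log units; beyond the scatter)), so the gap first seen with compound 1 does not depend on one particular ring. Moving the ring oxygen, with oxolan-2-yl in place of oxolan-3-yl on the chain carbon, gives a step that this assay cannot separate from repeat-measurement noise (a 1.7-fold higher number from compound 1 to compound 3 (0.23 log units; within the scatter)), which means the oxygen's place in the ring makes no clear difference here. Across these three compounds, both oxolane-bearing groups therefore stand apart from the aromatic group, and none of the three goes against that pattern.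

On these data alone, each oxolane ring arrives together with the hydroxyl-bearing chain, so it remains open whether the ring or the hydroxyl goes with the lower clearance, a question that a methoxy in place of the hydroxyl, or an oxolane ring bound directly to the aromatic carbon, could help to settle. The compounds shown also come with no measurement that explains the differences between them.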